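This account rests on a few compounds, and the source may have more. Where it says the series, first, only, none or still open, it means among the compounds named here.

Working notes on the series, read in an ADME assay on J774 cells (Mus musculus) for cytotoxicity; a lower number here means that less compound is needed, a higher number that more compound is needed for the effect. Compound 1 `COC(=O)c1c[nH]c2ccccc2c1=O` gives > 20000 nM, which is a limit of the assay. Compound 3 `COC(=O)c1c[nH]c2cc(Cl)ccc2c1=O`, the chloro member, gives > 20000 nM, again a limit and not a number. Compound 2 `COC(=O)c1c[nH]c2cc(Oc3ccccc3)ccc2c1=O`, the phenoxy member, gives a measured 9120 nM. Compound 3 thus stands with compound 1 at the limit of > 20000 nM in this assay, at which 2 of the 3 values shown sit.

The next change leads to compound 4 `COC(=O)c1c[nH]c2cc(-c3ccccc3)ccc2c1=O`: phenyl in place of chloro on an aromatic carbon. For the measured compounds named here, two measured steps bear on it most directly, an at least 2.1-fold lower number from compound 1 to compound 2 (0.34 log units; beyond the scatter) and an at least 2.1-fold higher number from compound 2 to compound 3 (0.34 log units; beyond the scatter). Both are at least modest, and their true size is hidden by the limit. The chloro step, a step that the two limits leave unreadable from compound 1 to compound 3, gives no size to work from.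

Going by the values given here, compound 4 has no direct precedent, but phenyl shares its aromatic ring with the phenoxy group of compound 2, which reads 9120 nM. A modest move to a lower number than the limit of compound 3 is therefore expected in this assay, although a reading back at the limit remains possible. The expected change is an at least 1.8-fold lower number from compound 3 to compound 4 (0.25 log units; that floor lies within the scatter). For compound 4 the estimated value is 11000 nM, with an expected range of 5000 nM to 20000 nM.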

Compound 4, half-maximal effective concentration: > 20000 nM
Compound 4: a limit, no number; the forecaster's own chance of this, stated with the estimate: 35%; at least 1.8-fold (0.25 log units) between middle value and limit.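

In this assay the phenyl member, compound 4, gives > 20000 nM, which is a limit of the assay and not a number. Phenyl in place of phenoxy on this aromatic carbon gives an at least 2.1-fold higher number from compound 2 to compound 4 (0.34 log units; beyond the scatter), so a six-membered aromatic ring of carbon only at this place does not by itself bring the reading off the limit, and among the compounds shown only the phenoxy member, compound 2, gives a number. The steps to compound 4 from compound 1 and from compound 3 cannot be read, both ends being limits, and the series now gathers at a single reading: the limit of > 20000 nM in this assay, at which 3 of the 4 values shown sit.

For the compounds shown here, how far compound 1, compound 3 and compound 4 lie from one another stays hidden behind the limit, so only one measured number anchors the series at this position. As far as these compounds go, whether the reading of compound 2 depends on the oxygen of the phenoxy group or on the group as a whole stays open, as does what a benzyloxy group, an amine or a carboxylic acid would give on the same aromatic carbon.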